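Working notes: replacing 3-fluorophenyl on compound 3

The source may report more compounds than this note shows. Statements on the series, on what has been measured and on what is new or still open speak of the compounds shown alone.

Measured so far in a functional assay on G-361 cells (Homo sapiens) for inhibition, with a stated time of 72 h; a lower number here means a stronger inhibitor, a higher number a weaker inhibitor:
- compound 1 `NC1CCC(Nc2nc(NCc3ccc(-c4ccccc4)cc3)c3ncn(C4CCCC4)c3n2)CC1` gives 1020 nM
- compound 2 `COc1ccccc1-c1ccc(CNc2nc(NC3CCC(N)CC3)nc3c2ncn3C2CCCC2)cc1` gives 545 nM
- compound 3 `NC1CCC(Nc2nc(NCc3ccc(-c4cccc(F)c4)nc3)c3ncn(C4CCCC4)c3n2)CC1` gives 49 nM

Compound 3 has the lowest number of the three, and the values of compound 2 and compound 1 both lie higher, beyond the scatter. Next in the series is compound 4 `NC1CCC(Nc2nc(NCc3ccc(-c4ccccc4O)nc3)c3ncn(C4CCCC4)c3n2)CC1`, with 2-hydroxyphenyl in place of 3-fluorophenyl on an aromatic carbon. The site is on a six-membered aromatic ring with 1 nitrogen, next to the ring nitrogen, para to a large group.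

Among the measured compounds shown here, no measured step makes this exchange. For the measured compounds named here, the only single-place step is methoxy in place of hydrogen on an aromatic carbon, a 1.9-fold lower number from compound 1 to compound 2 (0.27 log units; within the scatter), and compound 2 lacks the ring nitrogen of compound 3, so this is weak guidance. On that step, no change beyond the scatter is expected in this assay. The expected step is a 1.4-fold higher number from compound 3 to compound 4 (0.15 log units; within the scatter). The estimated value for compound 4 is 70 nM, with an expected range from 20 nM to 240 nM.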

Compound 4, half-maximal inhibitory concentration: 24 nM
Estimate against measurement, compound 4: 2.9-fold (0.46 log units) above; the measured number falls inside the stated range.
By their numbers in this assay, from the lowest: compound 4; then compound 3; then compounds 2 and 1 (each within the scatter of the next).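

In this assay, among the compounds shown here, the exchange of 3-fluorophenyl for 2-hydroxyphenyl gives a 2.0-fold lower number from compound 3 to compound 4 (0.31 log units; beyond the scatter), a modest step and the only single-place step read so far at this aromatic carbon next to the ring nitrogen. The position therefore tolerates this change of aryl group without a rise in the number, even though the entering group carries a hydrogen-bond donor and acceptor that the leaving group lacks. Nothing available accounts for the size or direction of this step.

The step changes both the substituent and its place on the phenyl ring, so 2-fluorophenyl and 3-hydroxyphenyl would be needed to separate the two. As far as these compounds go, whether 2-aminophenyl or 2-carboxyphenyl would sit with 2-hydroxyphenyl at this position remains open.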